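Methoxy for hydrogen on a diaryl pyridine core

The source may report more compounds than this note shows. Statements on the series, on what has been measured and on what is new or still open speak of the compounds shown alone.

Compounds measured:
compound 1, `COc1ccc(-c2c(C#N)c(N)c(C#N)c(SC)c2-c2ccc(F)cc2)cc1`: 13.4%
compound 2, `CSc1c(C)c(-c2ccccc2)c(C#N)c(N)c1C#N`: 6.7%

Of the compounds shown here, two have been measured in an assay on isolated protein for inhibition of Maltase-glucoamylase (Homo sapiens), tested at 100 uM; on this read-out higher numbers stand for more inhibition at the one concentration tested (going by the name of the read-out) and lower numbers for less inhibition. Compound 1 gives 13.4%, and compound 2 gives 6.7%. Compound 2 is the one giving the smaller of the two numbers, but the gap to compound 1 lies within the usual scatter of repeated measurements, so the two cannot be separated on this evidence.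

Compound 3, `COc1ccc(-c2c(C)c(SC)c(C#N)c(N)c2C#N)cc1`, has not been measured. It differs from compound 2 in one place: methoxy in place of hydrogen on an aromatic carbon. Compound 1 also carries a methoxy group, yet it differs from compound 2 in more than one place, so no single step can be read from the measured pair. With both measured numbers so close together, a step from compound 2 to compound 3 that stays within the scatter is expected, in no particular direction; the expected step is a number 2.3 percentage points higher from compound 2 to compound 3 (within the scatter).

For compound 3 in this assay, an estimated value of 9% is given, with an expected range from 1% to 19%.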

Compound 3, a percentage reported as inhibition, at one concentration (the size of the read-out at that concentration, not a potency): 17.3%
For compound 3 the middle estimate is 8.3 percentage points below the measured one, within the range that was stated.
By their numbers in this assay, from the lowest: compounds 2, 1 and 3 (each within the scatter of the next, the first and the last beyond it).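

In this assay, methoxy in place of hydrogen on an aromatic carbon, para to a large group, gives a number 10.6 percentage points higher from compound 2 to compound 3 (beyond the scatter), so this single change moves the read-out beyond the scatter, which the first two compounds, differing in more than one place, could not show. The second step, methyl in place of 4-fluorophenyl on an aromatic carbon, gives a number 3.9 percentage points higher from compound 1 to compound 3 (within the scatter), so in this pair, where both compounds carry the methoxy, that exchange does not separate them. Nothing measured in this set bears on why either number takes the value it does.

The compounds shown leave open whether the step belongs to methoxy in particular or would also appear with a hydroxyl, an ethoxy, a fluorine or an amine on the same aromatic carbon. They also leave open whether removing the methoxy from compound 1, which would show the same change with a 4-fluorophenyl in place of the methyl, would give a step of similar size, and whether a longer chain at that carbon would carry the read-out further.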